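A few compounds are considered here, and "the series" means these few. Any claim that something is new, unique, unknown or untested is made for them only; others in the source may bear on it.

The series shares one core throughout. Compound 1 `Cn1c(/C=C2/C(=O)Nc3ccc([N+](=O)[O-])cc32)nc2ccccc21` carries a methyl and a nitro group. In a functional assay on 4T1 cells (Homo sapiens) for cytotoxicity, read by MTT assay, with a stated time of 48 h (a higher number here means a weaker inhibitor, a lower number a stronger inhibitor), compound 1 returns only the limit > 50000 nM. Compound 2 `CCn1c(/C=C2/C(=O)Nc3ccc(Br)cc32)nc2ccccc21` carries an ethyl and a bromo. In this assay compound 2 gives 40700 nM. Compound 3 `CCn1c(/C=C2/C(=O)Nc3ccc(Cl)cc32)nc2ccccc21` carries an ethyl and a chloro. In this assay compound 3 returns only the limit > 50000 nM. For the measured compounds named here, the one measured step, an at least 1.2-fold higher number from compound 2 to compound 3 (0.08 log units; that floor lies within the scatter), is thus itself only a floor, and it rests on (the limit of > 50000 nM in this assay, at which 2 of the 3 values shown sit), at which compound 3 sits. Compound 3 therefore stands at the limit of this assay, as does compound 1.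

Compound 4 `CCn1c(/C=C2/C(=O)Nc3ccc([N+](=O)[O-])cc32)nc2ccccc21` is not yet measured. It differs from compound 3 by nitro in place of chloro on an aromatic carbon. Going by the values given here, no measured step covers this exchange. Among the compounds with values here, the only bearing comes from compound 1, which carries the same nitro group alongside a methyl rather than an ethyl and sits at the limit; compound 1 and compound 4 are not a measured pair, so only the two values speak. The expectation in this assay is a step of no size beyond the scatter, a step that the limit leaves unreadable from compound 3 to compound 4, with the value most likely reported again only as a limit. Compound 4 is therefore estimated at 60000 nM, within 30000 nM to 150000 nM.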

Compound 4, half-maximal inhibitory concentration: > 50000 nM
Compound 4: only a limit was reported (the forecaster's own chance of this, stated with the estimate: 70%); the middle value lies beyond the limit too.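

With the ethyl kept and nitro in place of bromo on the aromatic carbon, the result in this assay is an at least 1.2-fold higher number from compound 2 to compound 4 (0.08 log units; that floor lies within the scatter), and this is only a floor that does not set compound 4 apart from compound 2. The steps linking compound 4 to compound 3 and to compound 1 cannot be read, since both ends of each are limits. New here is that the nitro group now sits at the limit with either the methyl or the ethyl, and that with the ethyl both nitro and chloro sit there, which leaves compound 2 as the only compound with a number rather than a limit: the limit of > 50000 nM in this assay, at which 3 of the 4 values shown sit.

Where compound 1, compound 3 and compound 4 really lie stays open, and so does whether methyl and ethyl differ at all when the nitro group is present. Also open, on these data alone, is how an amine or a carboxylic acid at this position on the six-membered aromatic ring, or a longer chain in place of the ethyl, would read in this assay.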